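The source may report more compounds than this note shows. Statements on the series, on what has been measured and on what is new or still open speak of the compounds shown alone.

Measured in a functional assay on FM3A cells (Mus musculus) for cytotoxicity, read by cell counting, with a stated time of 2 days; on this read-out higher numbers stand for weaker inhibition and lower numbers for stronger inhibition:
compound 1, `C=C(Br)C(=O)Nc1cccc(/C=C2\SC(=O)N(Cc3cccc(F)c3)C2=O)c1`: 690 nM
compound 2, `C=C(Br)C(=O)Nc1cccc(/C=C2\SC(=O)N(Cc3ccc(Cl)cc3)C2=O)c1`: 1600 nM
compound 3, `Nc1ccc(/C=C2\SC(=O)N(Cc3cccc(F)c3)C2=O)cc1`: 121000 nM

Compound 1 and compound 2 differ in one place, (4-chlorophenyl in place of 3-fluorophenyl on a saturated chain carbon bound to an amide-type nitrogen in a ring), and this change gives a 2.3-fold higher number from compound 1 to compound 2 (0.37 log units; beyond the scatter). Compound 3 has a different core from compound 1; the difference between the two cores is not broken down here. Compound 3 stands far from the other two and is the weakest inhibitor of the three in this assay.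

Compound 4, `Nc1ccc(/C=C2\SC(=O)N(Cc3ccc(Cl)cc3)C2=O)cc1`, is not yet measured. It differs from compound 3 by 4-chlorophenyl in place of 3-fluorophenyl on a saturated chain carbon bound to an amide-type nitrogen in a ring, the same change as between compound 1 and compound 2. Compound 4 is expected to show a 1.8-fold higher number from compound 3 to compound 4 (0.26 log units; within the scatter). Within the data shown here, this expectation rests on compound 1 and compound 2 alone, because a 2.3-fold higher number from compound 1 to compound 2 (0.37 log units; beyond the scatter) is the only earlier instance of the change. The estimate for compound 4 is 220000 nM, between 80000 nM and 600000 nM.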

Compound 4, half-maximal inhibitory concentration: 60000 nM
Compound 4: the middle estimate sits 3.7-fold (0.56 log units) above what was measured, outside the stated range (below it).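

In this assay, the exchange of 3-fluorophenyl for 4-chlorophenyl does not carry over unchanged from the core of compound 1 to the core of compound 3: the same change on two cores in this assay, a 2.3-fold higher number (0.37 log units; beyond the scatter) from compound 1 to compound 2 and a 2.0-fold lower number (0.30 log units; within the scatter) from compound 3 to compound 4, 4.7-fold (0.67 log units) apart, beyond the scatter of two such steps. On the second core the exchange gives a 2.0-fold lower number from compound 3 to compound 4 (0.30 log units; within the scatter), a step too small to separate the two compounds. With one pair per core, this shows no reversal of direction, the second step lying within the scatter, and it does not say which difference between the cores matters.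

Open, going by these compounds, is how the step behaves with an unsubstituted phenyl or a 4-methoxyphenyl on that saturated chain carbon. Also open, on these data alone, is what a plain acetamide would give in place of the bromine-bearing amide group on the core of compound 1.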